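Piperazine substituent swap on the aminopyrimidine series

The compounds below may be only part of what the source reports. "The series", "measured", "known", "first", "only" and "open" are said of these compounds alone.

Two compounds of this series have been run in a functional assay on cells (T-cell, Homo sapiens) for inhibition; on this read-out lower numbers stand for stronger inhibition and higher numbers for weaker inhibition. Compound 1 `COc1ccc(-c2cnc3nc(N)nc(OC(C)C)c3n2)cc1` returns only a limit, > 10000 nM, at which one of the two reported values sits (the limit of > 10000 nM in this assay, at which 1 of the 2 values shown sits). Going by the values given here, compound 2 `COc1ccc(-c2cnc3nc(N)nc(N4CCN(C(=O)c5ccccc5)CC4)c3n2)cc1OC` gives 400 nM, the only actual number in the set. Among the compounds with values here, no measured pair differs in one place, so no step size is recorded here.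

Compound 3 `COc1ccc(-c2cnc3nc(N)nc(N4CCN(c5ccc(F)cc5)CC4)c3n2)cc1OC` has not yet been tested. It differs from compound 2 by the change (4-fluorophenyl in place of benzoyl on an amine nitrogen in a ring). Nothing in the two measured values bears on this change, so the direction of the step is open. The expectation is a step of modest size, with weaker inhibition somewhat more likely than stronger, a 1.8-fold higher number from compound 2 to compound 3 (0.24 log units; within the scatter). Compound 3 is therefore estimated to give 700 nM, in the range 150 nM to 3500 nM.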

Compound 3, half-maximal inhibitory concentration: 100 nM
The estimate for compound 3 lay 7.0-fold (0.85 log units) above the measured number; measured number below the stated range.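

On the amine nitrogen in a ring, 4-fluorophenyl in place of benzoyl gives, in this assay, a 4.0-fold lower number from compound 2 to compound 3 (0.60 log units; beyond the scatter). The group on this nitrogen therefore moves the read-out beyond the scatter, and compound 3 reaches 100 nM with a group that has 0 hydrogen-bond acceptors, so the carbonyl of benzoyl is not required for inhibition at this level. Nothing measured here gives a property that would account for the step.

Still open, as far as these compounds go, is whether the step belongs to the fluorine, to the loss of the carbonyl, or to the aromatic ring sitting directly on the nitrogen. A plain phenyl, a benzyl or a 4-methoxyphenyl on the same nitrogen would separate these readings.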